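The compounds below may be only part of what the source reports. "The series", "measured", "known", "first", "only" and "open" are said of these compounds alone.

Measured compounds:

compound 1, `CC(O)(CSc1ccc(C(F)(F)F)cc1)C(=O)Nc1ccc(S(F)(F)(F)(F)F)cc1`, with 14800 nM in a functional assay on CWR22R cells (Homo sapiens) for antiproliferative activity, read by propidium iodide staining, with a stated time of 96 h; a lower number here means a stronger inhibitor, a higher number a weaker inhibitor
compound 2, `CC(O)(CSc1cccc(C(F)(F)F)c1)C(=O)Nc1ccc(S(F)(F)(F)(F)F)cc1`, with 23400 nM
compound 3, `CC(O)(CSc1ccc(OC(F)(F)F)cc1)C(=O)Nc1ccc(S(F)(F)(F)(F)F)cc1`, with 14900 nM

All three share one core and differ only in the group carried on a sulfur and in the small group fixed to that aromatic ring. The cores of compound 1 and compound 2 differ as follows: 3-(trifluoromethyl)phenyl in place of 4-(trifluoromethyl)phenyl on a sulfur. That rearrangement gave a 1.6-fold higher number from compound 1 to compound 2 (0.20 log units; within the scatter). Exchanging the small group on the ring in compound 1 gives compound 3, a change described as trifluoromethoxy in place of trifluoromethyl on an aromatic carbon, and the outcome was a 1.0-fold higher number from compound 1 to compound 3 (0.00 log units; within the scatter), so compound 1 and compound 3 are indistinguishable in this assay.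

Compound 4, `CC(O)(CSc1cccc(OC(F)(F)F)c1)C(=O)Nc1ccc(S(F)(F)(F)(F)F)cc1`, has not yet been measured. It arises from compound 2 by trifluoromethoxy in place of trifluoromethyl on an aromatic carbon. For the measured compounds named here, this is the same kind of change as the one from compound 1 to compound 3, though not the same: there the entering group sits para to a large group, here it sits meta to a large group. Going by the values given here, with only one example of the exchange to go on, and that example showing no movement at all, the most reasonable expectation is that compound 4 stays close to compound 2, since the like step for compound 1 was a 1.0-fold higher number from compound 1 to compound 3 (0.00 log units; within the scatter). The expected step is therefore a 1.0-fold lower number from compound 2 to compound 4 (0.01 log units; within the scatter), which is within the scatter. On that basis compound 4 is estimated at 23000 nM, with a likely range from 11000 nM to 48000 nM.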

Compound 4, half-maximal inhibitory concentration: 14000 nM
Compound 4: middle estimate off by 1.6-fold (0.22 log units), on the high side; the range from low to high includes it.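

Placing trifluoromethoxy in place of trifluoromethyl on the ring attached to sulfur gave a 1.7-fold lower number from compound 2 to compound 4 (0.22 log units; within the scatter) in this assay, so on this second core the exchange again stays within the normal spread of repeated measurements. Set beside the first example, the two outcomes cannot be told apart: the same change on two cores in this assay, a 1.0-fold higher number (0.00 log units; within the scatter) from compound 1 to compound 3 and a 1.7-fold lower number (0.22 log units; within the scatter) from compound 2 to compound 4, 1.7-fold (0.23 log units) apart, within the scatter of two such steps This shows that, within the limits of the assay, the exchange behaved alike on the core of compound 1 and the core of compound 2, but two pairs cannot establish a general rule for other cores, and a small real difference between the two groups, or between the two cores, could remain hidden within the scatter.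

The compounds shown leave open whether a different small group on that ring, such as a nitrile, a chlorine atom or a methoxy group, would shift the number by more than the scatter on either core. They also leave open how the number would respond to changes elsewhere in the molecule, such as a sulfonyl group in place of the sulfur or an amine in place of the hydroxyl group.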